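The compounds below may be only part of what the source reports. "The series", "measured", "known", "first", "only" and "open" are said of these compounds alone.

Going by the values given here, compound 3 `CCc1nc2c(C)cc(C)nc2n1Cc1ccc(OC(C(=O)O)c2ccccc2)c(Cc2ccccc2)c1` has the highest number of the three compounds measured so far in an assay on Midbrain with Type-2 angiotensin II receptor (Rattus norvegicus) as the target; a lower number here means a stronger inhibitor, a higher number a weaker inhibitor. In this assay compound 3 gives 800 nM, while compound 1 `CCCCc1cc(Cn2c(CC)nc3c(C)cc(C)nc32)ccc1OC(C(=O)O)c1ccccc1` gives 140 nM and compound 2 `C=CCc1cc(Cn2c(CC)nc3c(C)cc(C)nc32)ccc1OC(C(=O)O)c1ccccc1` gives 270 nM. The step of a 5.7-fold higher number from compound 1 to compound 3 (0.76 log units; beyond the scatter) and the step of a 3.0-fold higher number from compound 2 to compound 3 (0.47 log units; beyond the scatter) both run to compound 3, whereas the step of a 1.9-fold higher number from compound 1 to compound 2 (0.29 log units; within the scatter) stays within the scatter.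

Compound 4 `CCc1nc2c(C)cc(C)nc2n1Cc1ccc(OC(C(=O)O)c2ccccc2)c(OC)c1` is the next compound to be measured in this assay. It differs from compound 3 by methoxy in place of benzyl on an aromatic carbon. Among the compounds with values here, none of the measured steps exchanges benzyl for methoxy, so the comparison is indirect. The two steps that bear on it show that bringing a phenyl onto the saturated chain carbon at this place raised the number, by a 5.7-fold higher number from compound 1 to compound 3 (0.76 log units; beyond the scatter) and by a 3.0-fold higher number from compound 2 to compound 3 (0.47 log units; beyond the scatter). Taking the benzyl away again is therefore expected to lower the number in this assay by a modest step, a 3.2-fold lower number from compound 3 to compound 4 (0.51 log units; beyond the scatter). Compound 4 is accordingly estimated at 250 nM in this assay, with a likely range from 80 nM to 800 nM.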

Compound 4, half-maximal inhibitory concentration: 2900 nM
Beside the measured number, compound 4's estimate is 12-fold (1.06 log units) below it; measured number outside the range, above it.
By their numbers in this assay, from the lowest: compounds 1 and 2 (each within the scatter of the next); then compound 3; then compound 4.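

Going by these compounds alone, at this place, on an aromatic carbon ortho to a carboxy(phenyl)methoxy group, the earlier compounds carried only carbon-linked groups, and methoxy is the first to join the ring through oxygen. In this assay, replacing those groups with methoxy gives a 3.6-fold higher number from compound 3 to compound 4 (0.56 log units; beyond the scatter), an 11-fold higher number from compound 2 to compound 4 (1.03 log units; beyond the scatter) and a 21-fold higher number from compound 1 to compound 4 (1.32 log units; beyond the scatter). Benzyl therefore no longer marks the weak end of this series: all three carbon-linked groups, including benzyl, give lower numbers than methoxy, and the two larger steps are those from allyl and butyl.

These compounds cannot separate the oxygen link from the shortness of the group, since an ethyl group or a propoxy chain at this place would be needed to tell the two apart. Nothing among the data shown explains the rise in the number.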